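Working notes: aryl substituent variation in a kinase binding series

This account rests on a few compounds, and the source may have more. Where it says the series, first, only, none or still open, it means among the compounds named here.

Measured compounds:
compound 1 `CCCS(=O)(=O)Nc1ccc(F)c(C(=O)c2n[nH]c3ncc(-c4ccccc4Cl)cc23)c1F`: 9.3%
compound 2 `CCCS(=O)(=O)Nc1ccc(F)c(C(=O)c2n[nH]c3ncc(-c4cccc(O)c4)cc23)c1F`: 2.2%
compound 3 `CCCS(=O)(=O)Nc1ccc(F)c(C(=O)c2n[nH]c3ncc(-c4ccc(Cl)cc4Cl)cc23)c1F`: 22%

In an assay for binding affinity to dual specificity mitogen-activated protein kinase kinase 4 (Homo sapiens), read by KINOMEscan, tested at 100 nM (on this read-out lower numbers stand for a stronger effect and higher numbers for a weaker effect at the one concentration tested), compound 3 gives the highest of the three numbers, that is the weakest effect. Its steps to both others are beyond the scatter: a number 12.7 percentage points higher from compound 1 to compound 3 (beyond the scatter) and a number 19.8 percentage points higher from compound 2 to compound 3 (beyond the scatter). Between the other two, a number 7.1 percentage points lower from compound 1 to compound 2 (within the scatter), so compounds 1 and 2 are not separated.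

Compound 4 `CCCS(=O)(=O)Nc1ccc(F)c(C(=O)c2n[nH]c3ncc(-c4ccc(Cl)c(Cl)c4)cc23)c1F` differs from compound 3 in one place: 3,4-dichlorophenyl in place of 2,4-dichlorophenyl on an aromatic carbon. The two have the same atoms, joined differently.

For the measured compounds named here, no measured step moves a chlorine from one position to another on this aryl group; the only steps that touch it are the modest upward ones from compound 1 and compound 2 to compound 3. Compound 4 keeps both chlorines of compound 3, so it is expected to stay close to compound 3 with the step of a number 5 percentage points lower from compound 3 to compound 4 (within the scatter), likely within the scatter, with the number of compound 1 as a plausible lower side. For compound 4 the estimate in this assay is 17%, expected between 6% and 35%.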

Compound 4, a percentage reported as activity, at one concentration (the size of the read-out at that concentration, not a potency): 45%
Beside the measured number, compound 4's estimate is 28 percentage points below it; measured number outside the range, above it.
By their numbers in this assay, from the lowest: compounds 2 and 1 (each within the scatter of the next); then compound 3; then compound 4.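

In this assay the arrangement of the two chlorines counts by itself: with the same atoms on the same aromatic carbon, the swap of 2,4-dichlorophenyl for 3,4-dichlorophenyl gives a number 23 percentage points higher from compound 3 to compound 4 (beyond the scatter) and is a modest step beyond the scatter, so the two dichlorophenyl groups are not interchangeable here. The steps to compound 4 from the two compounds at the low end are larger, with a number 42.8 percentage points higher from compound 2 to compound 4 (beyond the scatter) and a number 35.7 percentage points higher from compound 1 to compound 4 (beyond the scatter) both large, and compound 4 now marks the weakest effect of the four compounds in this assay with all its steps beyond the scatter. No supporting information on the origin of these differences is available.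

The compounds shown leave open which chlorine of compound 4 goes with its higher number, a question that 3-chlorophenyl and 4-chlorophenyl groups at the same carbon would separate. Also open, from the compounds shown here alone, is whether a 3-aminophenyl or 3-methoxyphenyl group would stay close to compound 2 or move toward compound 4.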